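Moving from pyridin-4-yl to pyridin-3-yl on the core

A few compounds are considered here, and "the series" means these few. Any claim that something is new, unique, unknown or untested is made for them only; others in the source may bear on it.

Measured in a functional assay on CNS cells (Homo sapiens) for antiproliferative activity; a lower number here means a stronger inhibitor of growth, a higher number a weaker inhibitor of growth:
Compound 1 `Cc1cn2c(/C=N/NC(=N)N)c(-c3ccncc3)nc2s1`: 16200 nM
Compound 2 `Cc1sc2nc(-c3ccncc3)c(/C=N/NC(=N)N)n2c1C`: 38900 nM

Compound 1 gives the lowest of the two numbers in this assay; its nearest neighbour is compound 2, and the step of a 2.4-fold higher number from compound 1 to compound 2 (0.38 log units; beyond the scatter) comes from a methyl in place of hydrogen on an aromatic carbon. Compound 3 `Cc1cn2c(/C=N/NC(=N)N)c(-c3cccnc3)nc2s1` has not yet been measured. It differs from compound 1 by pyridin-3-yl in place of pyridin-4-yl on an aromatic carbon, the two compounds holding the same atoms joined differently. The single measured step concerns a methyl group and says nothing about changing the attachment point of the pyridinyl group, so among these compounds there is no precedent for this move. With nothing to point either way, compound 3 is expected to land near compound 1 in this assay. The expected step for compound 3 is a 1.0-fold lower number from compound 1 to compound 3 (0.01 log units; within the scatter), within the scatter, though the absence of any guiding step makes the range wide. The estimate for compound 3 in this assay is 16000 nM, between 5000 nM and 50000 nM.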

Compound 3, concentration for 50% growth inhibition: 12000 nM
Compound 3: the middle estimate sits 1.3-fold (0.12 log units) above what was measured; the measured number falls inside the stated range.
By their numbers in this assay, from the lowest: compounds 3 and 1 (each within the scatter of the next); then compound 2.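

In this assay, placing pyridin-3-yl instead of pyridin-4-yl on this aromatic carbon of the five-membered aromatic ring gives a 1.4-fold lower number from compound 1 to compound 3 (0.13 log units; within the scatter), so the two attachment points of the pyridinyl group cannot be told apart in this assay. Going by these compounds alone, the earlier pair spoke only of a methyl group elsewhere on the core, with a 2.4-fold higher number from compound 1 to compound 2 (0.38 log units; beyond the scatter); this is the first reading at the position bearing the pyridinyl group, and it shows that moving the ring nitrogen, with the atoms otherwise unchanged, leaves the result within the scatter. No evidence is available on what lies behind this result.

The compounds shown leave open whether the position tolerates other rings as well, since neither pyridin-2-yl nor a phenyl ring with no ring nitrogen appears among them, and an amine or a carboxylic acid on the pyridinyl ring is equally untested here. They also leave open whether pyridin-3-yl would give a comparable result on the core of compound 2, which carries the additional methyl group.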